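A few compounds are considered here, and "the series" means these few. Any claim that something is new, unique, unknown or untested is made for them only; others in the source may bear on it.

Among the measured compounds shown here, in a functional assay on PC-6 cells (Homo sapiens) for cytotoxicity, read by MTT assay, with a stated time of 3 days (a lower number here means a stronger inhibitor, a higher number a weaker inhibitor), compound 1 `CNCc1ccc(/C=N/Nc2ncnc3sc(C(C)(C)C)cc23)cc1` gives 0.044 ug/mL and is the only compound here with an exact number. Compound 2 `COC(=O)c1ccc(/C=N/Nc2ncnc3sc(C(C)(C)C)cc23)cc1` has the entry "not determined" (no result reported) and so adds nothing. Compound 3 `CC(C)(C)c1cc2c(N/N=C/c3ccc(O)cc3)ncnc2s1` reads > 10 ug/mL which is a limit of the assay and not a number.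

Compound 4 `CN(C)S(=O)(=O)c1ccc(/C=N/Nc2ncnc3sc(C(C)(C)C)cc23)cc1` differs from compound 3 in one place: dimethylsulfamoyl stands in place of hydroxy on an aromatic carbon, para to a large group (dimethylsulfamoyl in place of hydroxy on an aromatic carbon). For the measured compounds named here, one measured step bears on this change. It is an at least 220-fold higher number from compound 1 to compound 3 (2.35 log units; beyond the scatter) and it is large and beyond the scatter, with hydroxy as the incoming group. Losing hydroxy from compound 3 may therefore lower the number, though dimethylsulfamoyl has not been tested here, so a return all the way to the level of compound 1 at 0.044 ug/mL is not expected.

In this assay the estimated step is an at least 5.0-fold lower number from compound 3 to compound 4 (0.69 log units; beyond the scatter) and it is expected to run toward a lower number, which means a stronger inhibitor. Compound 4 is expected at about 2 ug/mL with an estimated range from 0.2 ug/mL to 10 ug/mL on this read-out.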

Compound 4, half-maximal inhibitory concentration: 2.12 ug/mL
Compound 4: middle estimate off by 1.1-fold (0.03 log units), on the low side, within the range that was stated.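

Putting dimethylsulfamoyl in place of hydroxy on this aromatic carbon, in this assay, gives an at least 4.7-fold lower number from compound 3 to compound 4 (0.67 log units; beyond the scatter), so the weak reading of compound 3 does not extend to every group other than (methylamino)methyl. Compound 3 stands at a limit of the assay and not at a number, so this step gives only its smallest possible size: the limit of > 10 ug/mL in this assay, at which 1 of the 4 values shown sits. Dimethylsulfamoyl in place of (methylamino)methyl still gives a 48-fold higher number from compound 1 to compound 4 (1.68 log units; beyond the scatter), so moving away from hydroxy closes only part of the gap to compound 1.

The compounds shown leave open whether a simple primary amine or a longer chain ending in an amine at this position would read as low as compound 1. They also leave open how a carboxylic acid there would read.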